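The source may hold more compounds than are shown below. What is called first, only, known or untested is meant among the compounds shown, and "the series" means these compounds.

In a functional assay on HCT-15 cells (Homo sapiens) for cytotoxicity, read by CCK-8 assay, with a stated time of 4 days (on this read-out higher numbers stand for weaker inhibition and lower numbers for stronger inhibition), compound 1, `Oc1ccc(-c2cc(-c3cccc(O)c3)nc(-c3cccc(O)c3)c2)cc1`, gives 3810 nM. Compound 2, `Oc1cccc(-c2cc(-c3ccccc3O)cc(-c3cccc(O)c3)n2)c1`, gives 5150 nM in this assay. Compound 3, `Oc1ccc(-c2cc(-c3cccc(O)c3)cc(-c3ccc(O)cc3)n2)cc1`, reaches only a limit in this assay, > 50000 nM, and is reported as no number; this is the limit of > 50000 nM in this assay, at which 1 of the 3 values shown sits.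

Among the two numbers shown, compound 1 stands lowest, with compound 2 the nearest, and the pair lies within the scatter of this assay. Among the compounds with values here, the one measured step that exchanges one hydroxyphenyl for another, a 2-hydroxyphenyl in place of a 4-hydroxyphenyl, runs a 1.4-fold higher number from compound 1 to compound 2 (0.13 log units; within the scatter).

Compound 4, `Oc1ccc(-c2cc(-c3cccc(O)c3)nc(-c3ccccc3O)c2)cc1`, is the next member and has not yet been measured in this assay. It differs from compound 1 as follows: 2-hydroxyphenyl in place of 3-hydroxyphenyl on an aromatic carbon. Within the data shown here, the only measured step that bears on this change is the one from compound 1 to compound 2, which moved a hydroxyphenyl attachment to the 2-position and stayed within the scatter. On that basis the step is expected to be a 1.2-fold higher number from compound 1 to compound 4 (0.07 log units; within the scatter), with no direction claimed beyond the scatter. Compound 4 is therefore estimated at 4500 nM, within a range of 2000 nM to 12000 nM, in this assay.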

Compound 4, half-maximal inhibitory concentration: 5830 nM
Beside the measured number, compound 4's estimate is 1.3-fold (0.11 log units) below it; the measured number falls inside the stated range.
By their numbers in this assay, from the lowest: compounds 1, 2 and 4 (each within the scatter of the next). At a limit, above all of these: compound 3.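

In this assay, 2-hydroxyphenyl in place of 3-hydroxyphenyl on the aromatic carbon next to the ring nitrogen gives a 1.5-fold higher number from compound 1 to compound 4 (0.18 log units; within the scatter). The earlier step changed the 4-hydroxyphenyl group of compound 1 instead and gave a 1.4-fold higher number from compound 1 to compound 2 (0.13 log units; within the scatter), so 2-hydroxyphenyl has now been read at two different places on the shared core, each time without a step beyond the scatter, a reading that covers compounds 1, 2 and 4 only. The compounds shown offer no measurement that gives a reason for this result.

Compound 3 gives only a limit, not a number, in this assay, > 50000 nM, and it differs from compound 1 in more than one place, so the change that separates it cannot be read from these compounds. Also open is what happens next to the ring nitrogen with a group other than a hydroxyphenyl, such as an unsubstituted phenyl, an aminophenyl or a carboxyphenyl, since only hydroxyphenyl groups appear in the compounds shown.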